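Sulfanyl gives way to dimethylamino on the shared core

The source may report more compounds than this note shows. Statements on the series, on what has been measured and on what is new or still open speak of the compounds shown alone.

For the measured compounds named here, compound 3 `OC[C@H]1OC(n2cnc3c(S)nccc32)[C@H](O)[C@@H]1O` is the only one of three compounds with a number rather than a limit in a functional assay on the whole organism (Pleural cavity) with Rattus norvegicus as the target (a higher number here means that more compound is needed for the effect, a lower number that less compound is needed), where compound 3 gives 9 mg/kg. Compound 1 `OC[C@H]1OC(n2cnc3c(Nc4ccccc4)nccc32)[C@H](O)[C@@H]1O` reaches only a limit, > 9 mg/kg. Compound 2 `CSc1nccc2c1ncn2[C@H]1C[C@H](O)[C@@H](CO)O1` likewise reaches only a limit, > 9 mg/kg. Going by the values given here, the single measured step, a number no higher from compound 1 to compound 3 (the limit leaves the size open), rests on the limit of > 9 mg/kg in this assay, at which 2 of the 3 values shown sit, and so leaves its size open. Compound 4 `CN(C)c1nccc2c1ncn2C1O[C@H](CO)[C@@H](O)[C@H]1O` differs from compound 3 by dimethylamino in place of sulfanyl on an aromatic carbon. Among the compounds with values here, no measured step involves a dimethylamino group, and compound 1, which carries anilino instead, sits at the limit. Compound 4 is therefore expected to show a step of a 1.3-fold higher number from compound 3 to compound 4 (0.12 log units; within the scatter), with a real chance of only a limit. The estimate for compound 4 is 12 mg/kg, between 5 mg/kg and 30 mg/kg.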

Compound 4, dose for half-maximal effect: > 9 mg/kg
Compound 4 ended at the assay's limit; the forecaster's own chance of this, stated with the estimate: 60%; the middle value lies beyond the limit too.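

Dimethylamino in place of sulfanyl on this aromatic carbon gives a number no lower from compound 3 to compound 4 (the limit leaves the size open) in this assay. The step from compound 1 to compound 4 cannot be read, so anilino and dimethylamino cannot be told apart here. Among the three groups now seen on this carbon, only sulfanyl gives a number, and the other readings stop at the same limit: the limit of > 9 mg/kg in this assay, at which 3 of the 4 values shown sit.

The compounds shown leave open how far compound 1 and compound 4 lie from compound 3. They also leave open whether a primary amine or a methoxy group here would give a number.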